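The source may hold more compounds than are shown below. What is called first, only, known or untested is meant among the compounds shown, and "the series" means these compounds.

Measured in a functional assay on HepG2 cells (Homo sapiens) for cytotoxicity, read by sulforhodamine B assay, with a stated time of 24 h; on this read-out higher numbers stand for weaker inhibition and lower numbers for stronger inhibition:
- compound 1 `O=C1Nc2ccc(S(=O)(=O)N3CCOCC3)cc2/C1=N/c1ccc(O)cc1`: 10400 nM
- compound 2 `CC(=O)N/N=C1\C(=O)Nc2ccc(S(=O)(=O)N3CCOCC3)cc21`: 27500 nM

Compound 2, at 27500 nM, holds the higher of the two numbers, so it is the weaker inhibitor of the pair. The next compound to consider is compound 3 `N/N=C1\C(=O)Nc2ccc(S(=O)(=O)N3CCOCC3)cc21`, which has hydrogen in place of acetyl on an amine nitrogen. Put another way, acetamido becomes amino.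

Within the data shown here, only one measured step bears on this, and only loosely, since it changes the same spot but not in the same way. It shows a 2.6-fold higher number from compound 1 to compound 2 (0.42 log units; beyond the scatter), with acetamido in place of 4-hydroxyphenyl on a double-bonded nitrogen. That swap of a larger group was modest, so only a small change is expected in this assay, with no firm direction and probably nothing beyond the scatter.

The expected step is a 1.4-fold lower number from compound 2 to compound 3 (0.14 log units; within the scatter). For compound 3 the estimated value is 20000 nM, with an expected range of 7000 nM to 60000 nM.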

Compound 3, half-maximal inhibitory concentration: 32400 nM
For compound 3 the middle estimate is 1.6-fold (0.21 log units) below the measured one; measured number inside the range.
By their numbers in this assay, from the lowest: compound 1; then compounds 2 and 3 (each within the scatter of the next).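

In this assay, hydrogen in place of acetyl on the amine nitrogen gives a 1.2-fold higher number from compound 2 to compound 3 (0.07 log units; within the scatter) and so the two compounds cannot be told apart on this read-out. Amino in place of 4-hydroxyphenyl on the double-bonded nitrogen gives a 3.1-fold higher number from compound 1 to compound 3 (0.49 log units; beyond the scatter) and this modest step, together with a 2.6-fold higher number from compound 1 to compound 2 (0.42 log units; beyond the scatter), leaves compound 1 as the strongest inhibitor of the three. No measurement shown here explains this difference.

As far as these compounds go, it remains open whether the hydroxyl of the 4-hydroxyphenyl group matters, which a plain phenyl or a 4-methoxyphenyl group on the same nitrogen could test. A longer acyl chain such as butanoyl in place of acetyl could also show whether this spot stays as flat as acetyl and hydrogen suggest.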